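The compounds below may be only part of what the source reports. "The series", "measured", "known", "first", "only" and "open" are said of these compounds alone.

Three compounds share one core. Compound 1 `C/C(=N\C#N)N(Cc1ccc(Cl)nc1)C(C)C` gives 1.46 in a physicochemical assay for lipophilicity, read by HPLC, using the shake flask method; a higher number here means a more lipophilic compound, a lower number a more polar compound. Compound 2 `CC(C)C/C(=N\C#N)N(C)Cc1ccc(Cl)nc1` gives 1.75 and compound 3 `CCC/C(=N\C#N)N(C)Cc1ccc(Cl)nc1` gives 1.55; both of these values lie within the scatter of compound 1, so the three cannot be told apart with confidence. Compound 4 `C/C(=N\C#N)NCc1ccc(Cl)nc1` differs from compound 1 in one place: hydrogen in place of isopropyl on an amine nitrogen. For the measured compounds named here, the only measured step of a related kind, which removes a single carbon from a chain, is a number 0.20 log units lower from compound 2 to compound 3 (within the scatter) and stays within the scatter. Going by the values given here, no measured step removes a group from the amine nitrogen, and this change removes three carbons, so a larger fall is expected, a number 0.81 log units lower from compound 1 to compound 4 (beyond the scatter). Compound 4 is therefore estimated at 0.65, between 0.15 and 1.15.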

Compound 4, partition coefficient: 1.07
Estimate against measurement, compound 4: 0.42 log units below; the measured number falls inside the stated range.
By their numbers in this assay, from the lowest: compound 4; then compounds 1, 3 and 2 (each within the scatter of the next).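

Putting hydrogen in place of isopropyl on the amine nitrogen gives, in this assay, a number 0.39 log units lower from compound 1 to compound 4 (beyond the scatter), a modest step. For the compounds shown here, it is the first step here to clear the scatter, as the one earlier step, on a saturated chain carbon, stayed within it. The compounds shown offer no measurement that explains the size of this step.

As far as these compounds go, whether an ethyl or a cyclopropyl group on this nitrogen would give a number between those of compound 4 and compound 1 remains open. So does the effect of a longer chain there, such as butyl.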